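The compounds below may be only part of what the source reports. "The series", "measured", "known", "first", "only" and "open" are said of these compounds alone.

Three compounds carry numbers in a physicochemical assay for inhibition, read by spectrophotometry, tested at 100 uM; on this read-out lower numbers stand for less inhibition and higher numbers for more inhibition at the one concentration tested (going by the name of the read-out). Compound 1 `CCOC(=O)NC(c1ccccc1)c1ccc(Cl)cc1` gives 21%. Compound 2 `COc1cc(NC(C)CCCNC(=O)NNC(=O)Nc2ccc(Cl)c(C(F)(F)F)c2)c2ncccc2c1` gives 63%, the second highest of the three: compound 3 `COc1ccc(/C(=N/NC(=O)NNC(=O)NCCCC(C)Nc2cc(OC)cc3cccnc23)c2ccccc2)cc1` gives 78%, a number above that of compound 2 by more than the scatter, while compound 1 lies far lower, also beyond the scatter. No two of these compounds differ in only one place, so no single step has been measured. Compound 4 `COc1cc(NC(C)CCCNC(=O)NNC(=O)NCCCO)c2ncccc2c1` is not yet measured in this assay; it differs from compound 2 in one place, (3-hydroxypropyl in place of 4-chloro-3-(trifluoromethyl)phenyl on an amide-type nitrogen). Among the compounds with values here, with no measured step to lean on, and compound 1 at 21% the only number beneath compound 2, a downward move is expected. The step of a number 18 percentage points lower from compound 2 to compound 4 (beyond the scatter) is expected to be downward and beyond the scatter. Compound 4 is expected to give 45%, within 25% to 68%.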

Compound 4, a percentage reported as inhibition, at one concentration (the size of the read-out at that concentration, not a potency): 45%
The estimate for compound 4 equals the measured number at the digits printed; measured number inside the range.
By their numbers in this assay, from the lowest: compound 1; then compound 4; then compound 2; then compound 3.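

Replacing 4-chloro-3-(trifluoromethyl)phenyl with 3-hydroxypropyl on the amide-type nitrogen gives, in this assay, a number 18 percentage points lower from compound 2 to compound 4 (beyond the scatter), the first single change measured in the series. This position therefore responds to its substituent, yet inhibition persists with no ring on this nitrogen. No available data bear on the reason for this step.

Within the data shown here, the single step swaps the ring, the halogens and the hydroxyl together, leaving open which part carries the difference. On these data alone, how a plain phenyl, a 3-aminopropyl or a longer hydroxyalkyl chain would read on the same nitrogen also remains open.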